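Bromo-substituted anilides against thiosulfate sulfurtransferase: working notes

This account rests on a few compounds, and the source may have more. Where it says the series, first, only, none or still open, it means among the compounds named here.

Measured so far:
- compound 1, `O=C(Nc1ccccc1)c1cccc(Br)c1O`: > 100000 nM
- compound 2, `O=C(Nc1ccccc1)c1cc(Br)ccc1O`: > 100000 nM
- compound 3, `O=C(Nc1cccc(Cl)c1)c1cccc(Br)c1`: > 100000 nM

Each of these three readings is a limit of an assay on isolated protein for inhibition of thiosulfate sulfurtransferase (Homo sapiens), with a stated time of 60 min, in the absence of a further agent (a lower number here means a stronger inhibitor, a higher number a weaker inhibitor), and not a number. Compound 2 sits at that limit, as do the other two; this is the whole of the evidence, summarised as the limit of > 100000 nM in this assay, at which 3 of the 3 values shown sit. Going by the values given here, no two measured compounds differ in one place only, so no measured step is available, and nothing ranks compound 2 against compound 1 or compound 3.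

Compound 4, `O=C(Nc1ccccc1)c1cc(Br)cc(Br)c1O`, is still to be measured in this assay. It differs from compound 2 in one place: bromo in place of hydrogen on an aromatic carbon.

With every value shown sitting at the limit, the expected step from compound 2 to compound 4 is a number no higher from compound 2 to compound 4 (the limit leaves the size open), that is, none beyond the scatter in either direction, a view resting only on (the limit of > 100000 nM in this assay, at which 3 of the 3 values shown sit). Compound 4 is therefore expected to return a result at or near the limit again, estimated at 100000 nM, with a range from 30000 nM to 300000 nM.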

Compound 4, half-maximal inhibitory concentration: > 100000 nM
Compound 4: only a limit was reported (the forecaster's own chance of this, stated with the estimate: 75%); the middle value lies on the limit itself.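

Compound 4 returns a limit, as do compound 1 and compound 2, so the steps from compound 1 and compound 2 to compound 4 cannot be read. The compounds shown leave open which change to the shared core, if any, would give a readable value in this assay.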